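The source may report more compounds than this note shows. Statements on the series, on what has been measured and on what is new or still open speak of the compounds shown alone.

Three compounds share one core and differ only in the group hanging from it. Compound 1 `CCCn1ccc2cc(-c3cccnc3)cc(Cl)c2c1=O` carries a six-membered aromatic ring with one nitrogen and nothing else on it, compound 2 `CCCn1ccc2cc(NCc3cccnc3)cc(Cl)c2c1=O` attaches a similar ring through an aminomethyl bridge, and compound 3 `CCCn1ccc2cc(-c3ccc(N(C)C)nc3)cc(Cl)c2c1=O` adds a dimethylamino group to the ring of compound 1. In a functional assay on CHO cells for agonist activity at metabotropic glutamate receptor 2 (Homo sapiens), read by GTPgammaS binding (a lower number here means that less compound is needed, a higher number that more compound is needed for the effect), compound 1 gives 631 nM, compound 2 gives 3160 nM and compound 3 gives 5010 nM. Compound 3 thus sits at the high end of these numbers: compound 2 lies within the scatter of it, while the step of a 7.9-fold higher number from compound 1 to compound 3 (0.90 log units; beyond the scatter) lies beyond the scatter. Compound 4 `CCCn1ccc2cc(-c3ccc(OC)nc3)cc(Cl)c2c1=O` differs from compound 3 by a single change: methoxy in place of dimethylamino on an aromatic carbon. For the measured compounds named here, the only measured step that touches this spot is a 7.9-fold higher number from compound 1 to compound 3 (0.90 log units; beyond the scatter), which shows that placing dimethylamino on the bare ring carbon pushes the number up considerably. Methoxy is a different, smaller substituent at the same spot, so the expectation is that compound 4 falls between the bare ring of compound 1 and the dimethylamino of compound 3, an estimated step of a 2.5-fold lower number from compound 3 to compound 4 (0.40 log units; beyond the scatter). The estimate for compound 4 is 2000 nM, with a range from 630 nM to 6300 nM.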

Compound 4, half-maximal effective concentration: 794 nM
The estimate for compound 4 lay 2.5-fold (0.40 log units) above the measured number; measured number inside the range.
By their numbers in this assay, from the lowest: compounds 1 and 4 (each within the scatter of the next); then compounds 2 and 3 (each within the scatter of the next).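

For the compounds shown here, until now, dimethylamino was the only group seen on this aromatic carbon, next to the ring nitrogen, so any substituent there might have been expected to raise the number in this assay. Methoxy does not follow that reading: replacing dimethylamino gives a 6.3-fold lower number from compound 3 to compound 4 (0.80 log units; beyond the scatter), whereas adding methoxy to the bare ring gives a 1.3-fold higher number from compound 1 to compound 4 (0.10 log units; within the scatter), which leaves compound 4 indistinguishable from compound 1 in this assay. The spot can therefore carry a substituent without a clear penalty, and the identity of the group decides the outcome, not merely the presence of one; no measurement at hand bears on why these two groups differ.

Going by these compounds, it remains open whether other groups at this spot, such as fluorine, methyl or a primary amine, would stay level with compound 1 and compound 4 or would resemble compound 3, and whether a longer chain such as ethoxy would behave like methoxy. On these data alone, it is also open whether the contrast between methoxy and dimethylamino would hold on the ring of compound 2, which is attached through an aminomethyl bridge.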